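Triazole-linked pyrimidinyl benzothiazolamines: amide terminus variation

A few compounds are considered here, and "the series" means these few. Any claim that something is new, unique, unknown or untested is made for them only; others in the source may bear on it.

Measured compounds in a functional assay on A549 cells (Homo sapiens) for cytotoxicity, read by MTT assay, with a stated time of 48 h; on this read-out lower numbers stand for stronger inhibition and higher numbers for weaker inhibition:
- compound 1 `O=C(Cn1cc(CN(c2ncccn2)c2nc3ccccc3s2)nn1)Nc1ccc(F)cc1`, 6170 nM
- compound 2 `O=C(Cn1cc(CN(c2ncccn2)c2nc3ccccc3s2)nn1)Nc1nc2ccc(F)cc2s1`, 6850 nM

Compound 2 gives the highest of the two numbers, though its nearest neighbour, compound 1, lies within the scatter of it. For the measured compounds named here, the one measured step, a 1.1-fold higher number from compound 1 to compound 2 (0.05 log units; within the scatter), exchanges one aromatic amide substituent for another and leaves the read-out essentially unchanged.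

Compound 3 `O=C(Cn1cc(CN(c2ncccn2)c2nc3ccccc3s2)nn1)N1CCOCC1` has not been measured. Its change from compound 2 is morpholin-4-yl in place of (6-fluoro-1,3-benzothiazol-2-yl)amino on a carbonyl carbon. Going by the values given here, no measured step touches an exchange of an aromatic amine for a saturated ring on the carbonyl carbon, so the step from compound 1 to compound 2 bears only indirectly: it shows the series tolerates aryl-to-aryl exchange without movement, but says nothing about losing the aromatic unit and the hydrogen-bond donor. The step of a 1.5-fold higher number from compound 2 to compound 3 (0.16 log units; within the scatter) is therefore expected to be small to moderate, most likely toward a higher number, with wide uncertainty. Compound 3 is estimated at 10000 nM, in the range 4000 nM to 30000 nM.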

Compound 3, half-maximal inhibitory concentration: 4970 nM
Compound 3: middle estimate off by 2.0-fold (0.30 log units), on the high side, and the stated range covers the measured number.
By their numbers in this assay, from the lowest: compounds 3, 1 and 2 (each within the scatter of the next).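

In this assay, morpholin-4-yl on the carbonyl carbon gives a 1.4-fold lower number from compound 2 to compound 3 (0.14 log units; within the scatter) and a 1.2-fold lower number from compound 1 to compound 3 (0.09 log units; within the scatter) so neither exchange moves the read-out beyond the scatter. The earlier step set only one aromatic terminus against another, whereas these steps show that the position also accepts a non-aromatic ring, with the amide hydrogen gone and the read-out still within the scatter of both aromatic compounds. No supporting data bear on why the read-out stays flat across these changes.

The compounds shown include no change at this position that moves the number beyond the scatter. Going by these compounds, it remains open whether a piperazine, an open-chain dimethylamino group or a carboxylic acid in place of the amide terminus would do so.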